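A few compounds are considered here, and "the series" means these few. Any claim that something is new, unique, unknown or untested is made for them only; others in the source may bear on it.

Measured compounds in a functional assay on HEK293 cells (Homo sapiens) for cytotoxicity; a lower number here means that less compound is tolerated, a higher number that more compound is tolerated:
- compound 1 `COc1ccc([C@H]2CC(=O)N(C(=O)c3ccccc3)C2)cc1OC1CCCC1`: compound 1 gives > 10000 nM, a limit of the assay.
- compound 2 `COc1ccc([C@H]2CC(=O)N(c3cccc(NC(=O)C(C)=O)c3)C2)cc1OC1CCCC1`: compound 2 gives > 10000 nM, also a limit of the assay.

Compound 2 stands at the limit of this assay, with no number of its own; the same holds for the other value shown, as the limit of > 10000 nM in this assay, at which 2 of the 2 values shown sit, records. Compound 3 `COc1ccc([C@H]2CC(=O)N(c3cccc(NS(=O)(=O)c4ccccc4Br)c3)C2)cc1OC1CCCC1` is not yet measured in this assay. It differs from compound 2 as follows: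

(2-bromophenyl)sulfonyl in place of acetylcarbonyl on a nitrogen on an aromatic ring

Among the compounds with values here, no step between two measured compounds is available, so the size of this change cannot be taken from the series. Given that both values shown sit at the limit, the step from compound 2 to compound 3 is expected to be a step that the limit leaves unreadable from compound 2 to compound 3, that is, none beyond the scatter. Compound 3 is estimated at 15000 nM in this assay, between 4000 nM and 50000 nM, most likely again reported only as a limit.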

Compound 3, half-maximal cytotoxic concentration: > 10000 nM
Compound 3 ended at the assay's limit (the forecaster's own chance of this, stated with the estimate: 70%); the middle value lies beyond the limit too.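

The step from compound 2 to compound 3 cannot be read in this assay, because both compounds sit at a limit of the assay: the limit of > 10000 nM in this assay, at which 3 of the 3 values shown sit.

The compounds shown leave open at what concentration, if any, each becomes cytotoxic, and whether (2-bromophenyl)sulfonyl in place of acetylcarbonyl changes this.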